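Replacing a para-trifluoromethyl aryl with a chloro aryl

A few compounds are considered here, and "the series" means these few. Any claim that something is new, unique, unknown or untested is made for them only; others in the source may bear on it.

Compound 2 `FC(F)(F)c1ccc(-c2nc(NCc3ccc(-c4cccnc4)cc3)c3ccccc3n2)cc1` gives "not active" (no number reported) in an assay on a protein complex for inhibition of ubiquitin carboxyl-terminal hydrolase 1/WD repeat-containing protein 48 (Homo sapiens), read by fluorescence; on this read-out lower numbers stand for stronger inhibition and higher numbers for weaker inhibition: for compound 2 the outcome was recorded in those words and nothing more, without a number. For the measured compounds named here, compound 1 `FC(F)(F)c1ccccc1-c1nc(NCc2ccc(-c3cncnc3)cc2)c2ccccc2n1`, the only related compound with a measured value, gives 3000 nM in this assay. Compound 3 `Clc1ccccc1-c1nc(NCc2ccc(-c3cccnc3)cc2)c2ccccc2n1` has not yet been measured. It differs from compound 2 in one place: 2-chlorophenyl in place of 4-(trifluoromethyl)phenyl on an aromatic carbon. Going by the values given here, compound 2 has no number; no step between measured compounds can be computed, and the size of the change from compound 2 to compound 3 in this assay cannot be stated against the scatter; all that can be said is that any measurable inhibition for compound 3 would be a move toward lower numbers relative to the inactive result for compound 2. With compound 1 giving 3000 nM as the only anchor, compound 3 is estimated at 5000 nM, with a range from 1500 nM to 20000 nM, and a real chance that compound 3 too is reported only as inactive.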

Compound 3, half-maximal inhibitory concentration: 2100 nM
For compound 3 the middle estimate is 2.4-fold (0.38 log units) above the measured one; the range from low to high includes it.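

For the compounds shown here, compound 2 has no number in this assay, so no step from it to compound 3 can be read, although compound 3 gives 2100 nM. The compounds shown leave open how much the change from 4-(trifluoromethyl)phenyl to 2-chlorophenyl shifts inhibition. No measurement shown here explains the difference in outcome.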